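The source may hold more compounds than are shown below. What is called first, only, known or untested is meant among the compounds shown, and "the series" means these compounds.

Compound 1 `COc1ccc([C@H]2CC(=O)N(c3ccc(N)cc3)C2)cc1OC1CCCC1` — in a functional assay on HEK293 cells (Homo sapiens) for cytotoxicity (on this read-out lower numbers stand for higher toxicity in this test and higher numbers for lower toxicity in this test), compound 1 gives > 10000 nM, which is a limit of the assay.
Compound 2 `COc1ccc([C@H]2CC(=O)N(c3ccc(C#N)cc3)C2)cc1OC1CCCC1` — in this assay compound 2 gives > 10000 nM, again a limit of the assay.
Compound 3 `COc1ccc([C@H]2CC(=O)N(c3ccccn3)C2)cc1OC1CCCC1` — in this assay compound 3 gives > 10000 nM, also a limit of the assay.

Compound 1 therefore stands at the limit and not at a number, and all three measured compounds sit at that same limit, as the limit of > 10000 nM in this assay, at which 3 of the 3 values shown sit, records. The steps a step that the two limits leave unreadable from compound 1 to compound 2 and a step that the two limits leave unreadable from compound 1 to compound 3 cannot be read in size, and the same holds for a step that the two limits leave unreadable from compound 2 to compound 3. The account now turns to compound 4 `COc1ccc([C@H]2CC(=O)N(c3cccc(S(C)(=O)=O)c3)C2)cc1OC1CCCC1`, which differs from compound 1 in one place: 3-(methylsulfonyl)phenyl in place of 4-aminophenyl on an amide-type nitrogen in a ring. Within the data shown here, no measured step bears readably on this change, since every change so far at the amide-type nitrogen in the ring has left the read-out at the limit. The step that the limit leaves unreadable from compound 1 to compound 4 is therefore expected to be none beyond the scatter. Compound 4 is expected to give 15000 nM, within 7000 nM to 40000 nM.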

Compound 4, half-maximal cytotoxic concentration: > 10000 nM
Compound 4: no number, only a limit (the forecaster's own chance of this, stated with the estimate: 85%); the middle value lies beyond the limit too.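

Compound 4 also stands at a limit of the assay, so the steps to it from compound 1, compound 2 and compound 3 cannot be read in size: the limit of > 10000 nM in this assay, at which 4 of the 4 values shown sit.

The compounds shown leave open how far any of the four lies beyond that limit in this assay, and whether any group on the amide-type nitrogen in the ring would give a number.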